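The compounds below may be only part of what the source reports. "The series", "measured", "known", "first", "only" and "open" are said of these compounds alone.

Compound 1 `CC(C)Oc1cc(-c2cncc(-c3cnn(C4COC4)c3)c2)ccc1C(N)=O` gives 200 nM in an assay on cells for inhibition of MAP kinase-interacting serine/threonine-protein kinase 1 (Homo sapiens), read by mobility shift assay, with stated times of 10 min and 60 min, in the presence of a further agent that is not named here; a higher number here means a weaker inhibitor, a lower number a stronger inhibitor. Compound 2 `Cc1[nH]ncc1-c1cncc(-c2ccc(C(N)=O)c(OC(C)C)c2)c1` gives 54 nM in this assay.

Compound 2 has the lower of the two numbers; its nearest neighbour is compound 1, with the step of a 3.7-fold lower number from compound 1 to compound 2 (0.57 log units; beyond the scatter). Compound 3 `CC(C)Oc1cc(-c2cncc(-c3cnn(C(C)C)c3)c2)ccc1C(N)=O` differs from compound 2 in one place: 1-isopropyl-1H-pyrazol-4-yl in place of 5-methyl-1H-pyrazol-4-yl on an aromatic carbon. Among the compounds with values here, only one measured step bears on this change, and it runs the other way: compound 1, whose pyrazole likewise carries a group on its nitrogen and no hydrogen-bond donor, lies higher than compound 2 by a 3.7-fold lower number from compound 1 to compound 2 (0.57 log units; beyond the scatter). Compound 3 is therefore expected to move back toward compound 1, by roughly a 2.8-fold higher number from compound 2 to compound 3 (0.44 log units; beyond the scatter). The estimate for compound 3 in this assay is 150 nM, within a range from 60 nM to 400 nM.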

Compound 3, half-maximal inhibitory concentration: 85 nM
Estimate against measurement, compound 3: 1.8-fold (0.25 log units) above; measured number inside the range.
By their numbers in this assay, from the lowest: compounds 2 and 3 (each within the scatter of the next); then compound 1.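

In this assay, the hydrogen-bond donor of the 5-methyl-1H-pyrazol-4-yl group is not needed to keep this level of inhibition: the change to 1-isopropyl-1H-pyrazol-4-yl, with no donor, gives a 1.6-fold higher number from compound 2 to compound 3 (0.20 log units; within the scatter). The group on the pyrazole nitrogen also counts: isopropyl in place of oxetan-3-yl gives a 2.4-fold lower number from compound 1 to compound 3 (0.37 log units; beyond the scatter). No measurement here explains either step.

From the compounds shown here alone, what a plain 1H-pyrazol-4-yl without the methyl would give stays open, as does the effect of an amine on the nitrogen substituent.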